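This account rests on a few compounds, and the source may have more. Where it says the series, first, only, none or still open, it means among the compounds named here.

Of the compounds shown here, three have so far been tested in an in vitro functional assay on 1321-N1 cells for agonist activity at P2Y purinoceptor 6 (Homo sapiens); on this read-out higher numbers stand for an effect only at larger amounts of compound and lower numbers for an effect already at smaller amounts. Compound 1 `Cn1c(=O)ccn([C@@H]2O[C@H](COP(=O)(O)OP(=O)(O)O)[C@@H](O)[C@H]2O)c1=O` gives 3300 nM, compound 2 `CCCCCCSc1ccn([C@@H]2O[C@H](COP(=O)(O)OP(=O)(O)O)[C@@H](O)[C@H]2O)c(=O)n1` gives 4900 nM, and compound 3 `O=c1ccn([C@]23CC2[C@H](COP(=O)(O)OP(=O)(O)O)[C@@H](O)C3)c(=O)[nH]1` gives 230 nM. Compound 2 thus stands at the highest of the three numbers; its value and that of compound 1 lie within the usual scatter of each other, whereas compound 3 sits clearly lower, a gap beyond the scatter. Compound 4 `O=C(O)CCSc1ccn([C@@H]2O[C@H](COP(=O)(O)OP(=O)(O)O)[C@@H](O)[C@H]2O)c(=O)n1` has not yet been measured. It differs from compound 2 in one place: carboxy in place of butyl on a saturated chain carbon, two bonds along the chain from a sulfur. Within the data shown here, no pair of measured compounds shows this change, so there is no direct precedent. In this assay the expected step is a 1.4-fold lower number from compound 2 to compound 4 (0.15 log units; within the scatter), that is, nothing beyond the scatter. Compound 4 is therefore estimated at 3500 nM, with a range from 900 nM to 14000 nM.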

Compound 4, half-maximal effective concentration: 1100 nM
Estimate against measurement, compound 4: 3.2-fold (0.50 log units) above; the measured number falls inside the stated range.
By their numbers in this assay, from the lowest: compound 3; then compound 4; then compounds 1 and 2 (each within the scatter of the next).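

In this assay the change from butyl to carboxy, on a saturated chain carbon two bonds along the chain from a sulfur, gives a 4.5-fold lower number from compound 2 to compound 4 (0.65 log units; beyond the scatter) and so shows that this position responds to what stands on it. A hexylsulfanyl group is thus not needed for an effect here, and (2-carboxyethyl)sulfanyl does better. Nothing at hand explains this step. Still open, from the compounds shown here alone, is whether the carboxy itself matters or merely the loss of the butyl. An amine, a methyl ester or a plain ethyl chain at this position could separate the two.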